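Changing the Cap Group on a Hydroxamic Acid Deacetylase Inhibitor

The compounds below may be only part of what the source reports. "The series", "measured", "known", "first", "only" and "open" are said of these compounds alone.

Measured compounds:
- Compound 1, `O=C(NO)c1ccc(Cn2nnc(Cc3ccccc3)n2)cc1`: 52 nM
- Compound 2, `O=C(NO)c1ccc(Cc2nc(-c3ccc(Cl)cc3)nn2Cc2ccccc2)cc1`: 368 nM
- Compound 3, `Cc1cc(-c2nnc(Sc3ccc(C(=O)NO)cc3)n2C)nn1C`: 5 nM

All three compounds were tested in an assay on Sf9 cells for inhibition of protein deacetylase HDAC6 (Homo sapiens), read by fluorescence; a higher number here means a weaker inhibitor, a lower number a stronger inhibitor. Each carries a hydroxamic acid on a benzene ring, joined through a linker to a five-membered ring rich in nitrogen that bears a further aromatic group, and they differ in how that outer group is attached and decorated. Among the three numbers, compound 1 stands second highest: compound 2 gives a higher number, a gap beyond the usual scatter, while compound 3 gives a lower number, also beyond the scatter. Compound 1 is therefore a moderate inhibitor in this set, neither the weakest nor the strongest.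

The unmeasured compound 4, `NCc1ccc(-c2nnn(Cc3ccc(C(=O)NO)cc3)n2)cc1`, differs from compound 1 in one place: 4-(aminomethyl)phenyl in place of benzyl on an aromatic carbon. The hydroxamic acid, its benzene ring and the nitrogen-rich five-membered ring are kept; only the outer group changes. Among the compounds with values here, no directly comparable pair among the measured compounds shows what such a swap does here, so the step can only be guessed from the general tolerance of this position in the measured set. In this assay, compound 1 would be expected to move little, with the estimated step of a 1.2-fold higher number from compound 1 to compound 4 (0.06 log units; within the scatter) lying within the scatter. Compound 4 is thus expected to give about 60 nM, with a likely range from 20 nM to 180 nM.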

Compound 4, half-maximal inhibitory concentration: 2 nM
Compound 4: the middle estimate sits 30-fold (1.48 log units) above what was measured, outside the stated range (below it).
By their numbers in this assay, from the lowest: compound 4; then compound 3; then compound 1; then compound 2.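

In this assay, putting 4-(aminomethyl)phenyl in place of benzyl on the aromatic carbon of the five-membered ring gives a 26-fold lower number from compound 1 to compound 4 (1.41 log units; beyond the scatter) and moves the compound from the middle of the set to the lowest number. The earlier compounds shown here differ from one another in several places at once, so they could not show that this single position matters; this step shows that the outer group alone can shift the number far beyond the scatter, towards a stronger inhibitor. The swap nevertheless bundles two changes, since the carbon link of benzyl disappears and an aminomethyl group arrives on the aromatic ring, and nothing available here explains the gain.

The compounds shown leave open which of these two changes carries the effect, a question that a plain phenyl group at this position, without the amine, would help to separate. They also leave open how much depends on the amine itself, which a hydroxymethyl group or a longer aminoethyl chain in its place could test.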